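Methyl for methoxy on the core of compound 1

A few compounds are considered here, and "the series" means these few. Any claim that something is new, unique, unknown or untested is made for them only; others in the source may bear on it.

Compound 1 `COc1ncnc2c1c(-c1ccsc1)cn2[C@@H]1O[C@H](CO)[C@@H](O)[C@H]1O`: 7640 nM
Compound 2 `COc1ncnc2c1c(-c1ccccc1)cn2[C@@H]1O[C@H](CO)[C@@H](O)[C@H]1O`: > 20000 nM

Among the compounds with values here, in a functional assay on CEM-DNR-bulk cells (Homo sapiens), read by MTT assay, with a stated time of 72 h (a lower number here means a stronger inhibitor, a higher number a weaker inhibitor), compound 1 gives 7640 nM, the only number among the values shown. Compound 2 gives > 20000 nM in this assay, which is a limit of the assay and not a number. Within the data shown here, the single measured step, an at least 2.6-fold higher number from compound 1 to compound 2 (0.41 log units; beyond the scatter), exchanges the group on the aromatic carbon and ends at the limit of > 20000 nM in this assay, at which 1 of the 2 values shown sits.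

Compound 3 `Cc1ncnc2c1c(-c1ccsc1)cn2[C@@H]1O[C@H](CO)[C@@H](O)[C@H]1O` differs from compound 1 by methyl in place of methoxy on an aromatic carbon. Among the measured compounds shown here, no measured step touches the methoxy of compound 1; the one step recorded concerns another part of the structure and gives no guide to this exchange. The expectation in this assay is therefore a step of no clear direction and not beyond the scatter, with the limit of the assay near. For compound 3 a step of a 1.3-fold higher number from compound 1 to compound 3 (0.12 log units; within the scatter) is expected. Compound 3 is estimated at 10000 nM, in the range 3000 nM to 30000 nM.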

Compound 3, half-maximal inhibitory concentration: 8560 nM
Compound 3: middle estimate off by 1.2-fold (0.07 log units), on the high side, within the range that was stated.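

In this assay, methyl in place of methoxy on this aromatic carbon of the core gives a 1.1-fold higher number from compound 1 to compound 3 (0.05 log units; within the scatter), so this assay does not separate the two groups here while the thiophen-3-yl group is held fixed. The oxygen and the hydrogen-bond acceptor counted for methoxy are therefore not needed to keep a measurable number in this series, whereas the exchange at the other place on the structure gives an at least 2.6-fold higher number from compound 1 to compound 2 (0.41 log units; beyond the scatter). Compound 3 gives a number, while the value of compound 2 remains a limit of the assay and not a number: the limit of > 20000 nM in this assay, at which 1 of the 3 values shown sits.

Going by these compounds, whether an amine, a chlorine atom or a longer chain such as ethoxy at this position would move the number beyond the scatter remains open. On these data alone, it is also open whether phenyl in place of thiophen-3-yl has the same outcome with methyl on the core.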